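The compounds below may be only part of what the source reports. "The series", "measured", "known", "first", "only" and "open" are said of these compounds alone.

Of the compounds shown here, three built on a shared core have so far been measured in an in vitro functional assay on 1321-N1 cells for antagonist activity at P2X purinoceptor 7 (Homo sapiens), read by FLIPR and calcium flux; a higher number here means a weaker inhibitor, a lower number a stronger inhibitor. Compound 1 `Fc1cccc(-c2nnnn2Cc2cccnc2)c1C(F)(F)F` gives 631 nM. Compound 2 `Fc1ccc(-c2nnnn2Cc2cccnc2)c(Cl)c1Cl` gives 12.6 nM. Compound 3 `Clc1cccc(-n2nnnc2Cc2cccnc2)c1Cl` gives 100 nM, the second highest of the three numbers; it stands closer to compound 1 than to compound 2, and both of those gaps lie beyond the usual scatter of repeated measurements.

Compound 4 `FC(F)(F)c1cccc(-n2nnnc2Cc2cccnc2)c1Cl` has not yet been measured in this assay. It differs from compound 3 in a single place: trifluoromethyl in place of chloro on an aromatic carbon. Among the compounds with values here, no pair among the measured compounds differs in exactly this way, so the direction and size of the step have no direct precedent here, and the three measured numbers give only a loose frame. The step from compound 3 to compound 4 is estimated at a 2.0-fold higher number from compound 3 to compound 4 (0.30 log units; within the scatter), a modest move toward a higher number that may still fall within the scatter. For compound 4 the expected value in this assay is 200 nM, with a range from 50 nM to 800 nM.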

Compound 4, half-maximal inhibitory concentration: 12.6 nM
Estimate against measurement, compound 4: 16-fold (1.20 log units) above; measured number below the stated range.
By their numbers in this assay, from the lowest: compounds 2 and 4 (each within the scatter of the next); then compound 3; then compound 1.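

In this assay, trifluoromethyl in place of chloro on an aromatic carbon gives a 7.9-fold lower number from compound 3 to compound 4 (0.90 log units; beyond the scatter), so the inhibitor becomes stronger even though 4 heavy atoms enter where 1 leaves. Within the data shown here, this is the first single-place step in the set, and it shows that the position, ortho to a chloro group and meta to a large group, both tolerates this larger group and responds to the change by more than the usual scatter. No measurement shown here accounts for this step.

On these data alone, it remains open whether the gain is particular to trifluoromethyl or would also appear with a methyl, a methoxy or a nitrile at this position. This single pair also cannot show whether the same swap would have a similar effect elsewhere in the series.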